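Swapping a Dichlorophenyl Ether for a Fluorophenyl Ether

This account rests on a few compounds, and the source may have more. Where it says the series, first, only, none or still open, it means among the compounds named here.

Compound 1, `Nc1cc(N)c2nc(-c3ccccc3)c(Oc3ccc(Cl)c(Cl)c3)nc2c1`, in a functional assay on SF-295 cells (Homo sapiens) for inhibition, read by sulforhodamine B assay, with a stated time of 48 h (on this read-out higher numbers stand for weaker inhibition of growth and lower numbers for stronger inhibition of growth), gives 30900 nM.
Compound 2, `CCOC(=O)[C@H](CCC(=O)O)NC(=O)c1ccc(Oc2nc3cc(N)cc(N)c3nc2-c2ccccc2)cc1`, in this assay gives < 100000 nM.

The value for compound 2 is a limit of this assay, not a number. For the measured compounds named here, compound 1 therefore holds the only real number here, while the other entry is a limit (the limit of < 100000 nM in this assay, at which 1 of the 2 values shown sits). Going by these compounds, compound 3, `Nc1cc(N)c2nc(-c3ccccc3)c(Oc3ccc(F)cc3)nc2c1`, is untested and differs from compound 1 by 4-fluorophenyl in place of 3,4-dichlorophenyl on an oxygen on an aromatic ring. Going by the values given here, no measured pair shows what such a change does, so the expected shift a 1.6-fold higher number from compound 1 to compound 3 (0.21 log units; within the scatter) is only modest, toward weaker inhibition. Compound 3 is estimated at 50000 nM, within 15000 nM to 150000 nM.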

Compound 3, concentration for total growth inhibition: 38900 nM
The estimate for compound 3 lay 1.3-fold (0.11 log units) above the measured number; the measured number falls inside the stated range.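

For the compounds shown here, the first measured step at this position shows that, in this assay, 4-fluorophenyl in place of 3,4-dichlorophenyl on an oxygen on an aromatic ring gives a 1.3-fold higher number from compound 1 to compound 3 (0.10 log units; within the scatter). This read-out therefore does not separate the ring with two chlorine atoms from the ring with one fluorine atom. Nothing in the information at hand bears on why this is so.

Going by these compounds, it remains open whether a phenyl ring carrying a nitrile or a methoxy group would give a similar number. The same holds for a plain alkyl chain on that oxygen in place of the ring.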